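Swapping nitro for amino on compound 3

The source may report more compounds than this note shows. Statements on the series, on what has been measured and on what is new or still open speak of the compounds shown alone.

Measured so far in a physicochemical assay for acid dissociation, are three compounds
Compound 1 `NS(=O)(=O)c1ccc(S(=O)(=O)CC(O)CO)cc1` gives 9.35
Compound 2 `NS(=O)(=O)c1ccc(SCCO)c([N+](=O)[O-])c1` gives 9.42
Compound 3 `NS(=O)(=O)c1ccc(S(=O)(=O)CCCO)c([N+](=O)[O-])c1` gives 8

Compound 3 holds the lowest of the three numbers. The gaps up to compound 1 and to compound 2 both lie beyond the scatter, and compound 1 is the nearer of the two. Compound 4 `Nc1cc(S(N)(=O)=O)ccc1S(=O)(=O)CCCO` has not yet been measured in this assay and differs from compound 3 by one change (amino in place of nitro on an aromatic carbon), amino in place of nitro on an aromatic carbon, ortho to a group of 7 heavy atoms and meta to a sulfamoyl group. Within the data shown here, no measured pair isolates this change, so any expectation rests on loose comparisons. Compound 1 carries neither nitro nor amino and stands at 9.35 on this scale, and compound 4 is expected to land near it. Compound 2 also carries nitro yet stands at 9.42 on the same scale, which adds caution. The expected step is a number 1.40 log units higher from compound 3 to compound 4 (beyond the scatter) upward, beyond the scatter. For compound 4 the estimated value is 9.4, with an expected range from 9 to 9.8 in this measurement.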

Compound 4, acid dissociation constant: 9.15
Beside the measured number, compound 4's estimate is 0.25 log units above it, and the stated range covers the measured number.
By their numbers in this assay, from the lowest: compound 3; then compounds 4, 1 and 2 (each within the scatter of the next).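

In this assay, among these compounds, this is the first pair that differs in one place, and it gives a number 1.15 log units higher from compound 3 to compound 4 (beyond the scatter) when amino replaces nitro on an aromatic carbon, ortho to a group of 7 heavy atoms and meta to a sulfamoyl group. Among the compounds shown here, it shows that this single exchange at this position is enough on its own to produce a large step, which the earlier compounds, none of them differing from another in only one place, could not show. Nothing available accounts for the size of this step.

The compounds shown leave open where a methoxy group or a chlorine on this same aromatic carbon would fall relative to amino and nitro. They also leave open whether the exchange of nitro for amino would give a step of similar size on the core of compound 2.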